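Cytotoxicity of a benzimidazole anilide and its free aniline

A few compounds are considered here, and "the series" means these few. Any claim that something is new, unique, unknown or untested is made for them only; others in the source may bear on it.

Measured compounds:
compound 1 `O=C(CN1CCCCC1)Nc1ccc(-c2nc3cc(Cl)c(Cl)cc3[nH]2)cc1` with > 100000 nM
compound 2 `O=C(CCl)Nc1ccc(-c2nc3cc(C(F)(F)F)ccc3[nH]2)cc1` with 35000 nM

Of the compounds shown here, two sharing a benzimidazole-aniline core have been tested in an ADME assay on Vero cells (Chlorocebus sabaeus) for cytotoxicity; a lower number here means that less compound is tolerated, a higher number that more compound is tolerated. For compound 1 the value given is a limit of this assay, not a number (the limit of > 100000 nM in this assay, at which 1 of the 2 values shown sits). Compound 2 carries a trifluoromethyl group on the core in place of two chlorines and a chloroacetyl group on the aniline nitrogen; in this assay compound 2 gives 35000 nM. Among the compounds with values here, compound 1 and compound 2 differ in more than one place, so their two values show only that compound 2 is tolerated at a lower concentration than the limit reached by compound 1.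

Compound 3 `Nc1ccc(-c2nc3cc(Cl)c(Cl)cc3[nH]2)cc1` is not yet measured. It differs from compound 1 as follows:
hydrogen in place of ((piperidin-1-yl)methyl)carbonyl on a nitrogen on an aromatic ring

Within the data shown here, with no single-change step measured, the size of this step is open. Compound 3 is expected to stay near the limit reached by compound 1, so the step of an at least 1.2-fold lower number from compound 1 to compound 3 (0.09 log units; that floor lies within the scatter) is estimated to be none beyond the scatter. The estimate for compound 3 is 80000 nM, within 20000 nM to 300000 nM.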

Compound 3, half-maximal cytotoxic concentration: >= 100000 nM
Compound 3 ended at the assay's limit; the forecaster's own chance of this, stated with the estimate: 50%; middle value at least 1.2-fold (0.09 log units) away from the limit.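

In this assay compound 1 gives > 100000 nM as a limit of the assay. Compound 3 gives >= 100000 nM as a limit of the assay too. With both values limits, the step between compound 1 and compound 3 cannot be read. The compounds shown leave open whether hydrogen in place of ((piperidin-1-yl)methyl)carbonyl changes the tolerated concentration at all, and by how much.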